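Fluoro in place of methoxy: working notes

A few compounds are considered here, and "the series" means these few. Any claim that something is new, unique, unknown or untested is made for them only; others in the source may bear on it.

Measured in a functional assay on MDA-MB-435 cells (Homo sapiens); on this read-out higher numbers stand for weaker inhibition of growth and lower numbers for stronger inhibition of growth:
- compound 1 `Cc1cnc2nc(-c3ccc(Cl)cc3)cc(O)c2c1`: 603 nM
- compound 2 `COc1ccc(-c2cc(O)c3cc(C)cnc3n2)cc1`: 1820 nM

Of these two, compound 2 has the higher number, 1820 nM, and so the weaker growth inhibition. The next compound, compound 3 `Cc1cnc2nc(-c3ccc(F)cc3)cc(O)c2c1`, differs from it by fluoro in place of methoxy on an aromatic carbon. Going by the values given here, the only measured step bearing on this is a 3.0-fold higher number from compound 1 to compound 2 (0.48 log units; beyond the scatter), methoxy in place of chloro. Read backwards, it points to a lower number on leaving methoxy, of similar or smaller size, though no fluoro compound has been measured yet. In this assay the expected step is a 2.0-fold lower number from compound 2 to compound 3 (0.31 log units; beyond the scatter). Compound 3 is estimated at 900 nM, with an expected range of 350 nM to 2200 nM.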

Compound 3, concentration for 50% growth inhibition: 2630 nM
Beside the measured number, compound 3's estimate is 2.9-fold (0.47 log units) below it, outside the stated range (above it).
By their numbers in this assay, from the lowest: compound 1; then compounds 2 and 3 (each within the scatter of the next).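

Read in this assay fluoro in place of methoxy on this aromatic carbon gives a 1.4-fold higher number from compound 2 to compound 3 (0.16 log units; within the scatter) and so does not separate the two groups. Fluoro in place of chloro gives a 4.4-fold higher number from compound 1 to compound 3 (0.64 log units; beyond the scatter) and so sets chloro apart, the only one of the three groups here with a lower number beyond the scatter. Nothing at hand explains this difference.

From the compounds shown here alone, whether an amine, a carboxylic acid or a longer chain such as ethoxy at this position would move the number beyond these three groups remains open. Also open, going by these compounds, is whether the chloro advantage holds with other changes to the shared core.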